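Chloro for methoxy on the sulfonyl aryl group

The source may report more compounds than this note shows. Statements on the series, on what has been measured and on what is new or still open speak of the compounds shown alone.

Measured in a functional assay on K562 cells (Homo sapiens) for inhibition, read by trypan blue exclusion, with a stated time of 72 h; on this read-out higher numbers stand for weaker inhibition and lower numbers for stronger inhibition:
- compound 1 `Cn1c(=O)c(S(=O)(=O)c2ccc(F)cc2F)cc2cnc(Nc3cccc4[nH]ccc34)nc21`: 1500 nM
- compound 2 `COc1ccc(Nc2ncc3cc(S(=O)(=O)c4ccc(Cl)cc4)c(=O)n(C)c3n2)cc1`: 15000 nM
- compound 3 `COc1ccc(S(=O)(=O)c2cc3cnc(Nc4cccc5[nH]ccc45)nc3n(C)c2=O)cc1`: 5000 nM

Compound 3, at 5000 nM, holds the middle place of the three numbers, with compound 1 lower and compound 2 higher, both gaps beyond the scatter. Compound 4 `Cn1c(=O)c(S(=O)(=O)c2ccc(Cl)cc2)cc2cnc(Nc3cccc4[nH]ccc34)nc21` differs from compound 3 in one place: chloro in place of methoxy on an aromatic carbon, which turns 4-methoxyphenyl into 4-chlorophenyl.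

Going by the values given here, one measured step bears directly on this group: a 3.3-fold higher number from compound 1 to compound 3 (0.52 log units; beyond the scatter), a modest change with 4-methoxyphenyl in place of 2,4-difluorophenyl on a sulfonyl sulfur. Among the compounds with values here, compound 2 reads 15000 nM and carries the same (4-chlorophenyl)sulfonyl as compound 4, but the two also differ in a second place, so the data hold no step for chloro alone. Compound 4 has a halogen on that phenyl, as does compound 1 at 1500 nM, so a modest move toward a lower number is expected in this assay, no larger than the measured step. The estimated change is a 2.2-fold lower number from compound 3 to compound 4 (0.34 log units; beyond the scatter). For compound 4 the estimated value is 2300 nM, with an expected range of 800 nM to 6500 nM.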

Compound 4, half-maximal inhibitory concentration: 5000 nM
For compound 4 the middle estimate is 2.2-fold (0.34 log units) below the measured one; measured number inside the range.
By their numbers in this assay, from the lowest: compound 1; then compounds 3 and 4 (each within the scatter of the next); then compound 2.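

In this assay, chloro in place of methoxy on the aromatic carbon gives no change at the digits printed from compound 3 to compound 4 (within the scatter), so the two groups cannot be told apart at this position, and a halogen on the phenyl does not by itself bring the number down to that of compound 1. The 2,4-difluorophenyl group keeps its edge over 4-chlorophenyl, with a 3.3-fold higher number from compound 1 to compound 4 (0.52 log units; beyond the scatter), so the lower number of compound 1 goes with that particular group rather than with halogen substitution in general, and compound 4 is the compound that goes against any such general reading. Going by these compounds alone, with (4-chlorophenyl)sulfonyl held constant, 1H-indol-4-yl in place of 4-methoxyphenyl on the nitrogen gives a 3.0-fold lower number from compound 2 to compound 4 (0.48 log units; beyond the scatter), which ties the other variable place to a clean step for the first time, though no measurement at hand explains this step or the others.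

The compounds shown leave open which of the two fluoro groups in 2,4-difluorophenyl goes with the lower number. They also leave open whether an amine or a carboxylic acid at the place held by chloro and methoxy would read any differently from these two groups.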